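A few compounds are considered here, and "the series" means these few. Any claim that something is new, unique, unknown or untested is made for them only; others in the source may bear on it.

In a functional assay on A549 cells (Homo sapiens) for inhibition, read by MTT assay, with a stated time of 72 h (on this read-out lower numbers stand for stronger inhibition and higher numbers for weaker inhibition), compound 1 `Clc1ccc(-c2nnc(SCCCN3CCN(c4nc5ccccc5o4)CC3)o2)cc1` gives 127000 nM and compound 2 `CC(C)(C)Oc1ccc(-c2nnc(SCCCN3CCN(c4nc5ccccc5o4)CC3)o2)cc1` gives 263000 nM so compound 1 holds the lower of the two numbers. Compound 3 `c1ccc(-c2nnc(SCCCN3CCN(c4nc5ccccc5o4)CC3)o2)cc1` carries hydrogen in place of chloro on an aromatic carbon and is not yet measured. Among the measured compounds shown here, one measured step bears on this place, a 2.1-fold higher number from compound 1 to compound 2 (0.32 log units; beyond the scatter) for tert-butoxy in place of chloro, and it is modest. For the measured compounds named here, with only that step as a guide, a modest move toward a higher number is expected in this assay and its direction remains uncertain. The expected step is a 1.4-fold higher number from compound 1 to compound 3 (0.15 log units; within the scatter) on this estimate. For compound 3 the estimate is 180000 nM with 80000 nM to 400000 nM as the expected range.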

Compound 3, half-maximal inhibitory concentration: 108000 nM
For compound 3 the middle estimate is 1.7-fold (0.22 log units) above the measured one; measured number inside the range.
By their numbers in this assay, from the lowest: compounds 3 and 1 (each within the scatter of the next); then compound 2.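

In this assay the chloro can be removed without a real change, with a 1.2-fold lower number from compound 1 to compound 3 (0.07 log units; within the scatter), so compound 1 and compound 3 cannot be ordered. The step of a 2.4-fold lower number from compound 2 to compound 3 (0.39 log units; beyond the scatter) shows that tert-butoxy, not chloro, is what separates from hydrogen at this place on the aromatic ring. No evidence is available to explain either step. Open, from the compounds shown here alone, is whether an amine, a carboxylic acid or a methoxy group at this place would move the number beyond the scatter. Changes to the propyl-type linking chain or the shared core also remain untested in these compounds.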